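Swapping the para substituent: acetyl to chloro

A few compounds are considered here, and "the series" means these few. Any claim that something is new, unique, unknown or untested is made for them only; others in the source may bear on it.

Measured compounds:
- compound 1 `COc1cc(Nc2nc(Nc3ccc(Br)cc3)nnc2Cl)cc(OC)c1OC`, in a functional assay on ECa-109 cells for inhibition, with ECa-109 cell line (Homo sapiens) as the target, read by MTT assay, with a stated time of 48 h (on this read-out lower numbers stand for stronger inhibition and higher numbers for weaker inhibition), compound 1 gives 41600 nM
- compound 2 `CCOC(=O)c1ccc(Nc2nnc(Cl)c(Nc3cc(OC)c(OC)c(OC)c3)n2)cc1`, in this assay compound 2 gives 46600 nM
- compound 3 `COc1cc(Nc2nc(Nc3ccc(C(C)=O)cc3)nnc2Cl)cc(OC)c1OC`, in this assay compound 3 gives 36300 nM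

Compound 3 has the lowest of the three numbers, yet it lies within the scatter of both others, so the three are not separable on these data. The new compound 4 `COc1cc(Nc2nc(Nc3ccc(Cl)cc3)nnc2Cl)cc(OC)c1OC` differs from compound 3 in one place: chloro in place of acetyl on an aromatic carbon. Among the compounds with values here, no measured step involves chloro itself, but the steps that exchange the same group are informative: a 1.1-fold lower number from compound 1 to compound 3 (0.06 log units; within the scatter), a 1.1-fold higher number from compound 1 to compound 2 (0.05 log units; within the scatter), and a 1.3-fold lower number from compound 2 to compound 3 (0.11 log units; within the scatter). Within the data shown here, every exchange at this position so far, including the one to bromo, a halogen, stayed within the scatter. A further halogen is therefore expected to give no step beyond the scatter, that is a 1.1-fold higher number from compound 3 to compound 4 (0.04 log units; within the scatter). Compound 4 is thus estimated at 40000 nM, with a range from 20000 nM to 80000 nM.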

Compound 4, half-maximal inhibitory concentration: 32600 nM
Compound 4: middle estimate off by 1.2-fold (0.09 log units), on the high side, and the stated range covers the measured number.
By their numbers in this assay, from the lowest: compounds 4, 3, 1 and 2 (each within the scatter of the next).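

In this assay chloro cannot be told apart from any of the three groups before it: the exchange reads (a 1.1-fold lower number from compound 3 to compound 4 (0.05 log units; within the scatter)) for acetyl, (a 1.3-fold lower number from compound 1 to compound 4 (0.11 log units; within the scatter)) for bromo and (a 1.4-fold lower number from compound 2 to compound 4 (0.16 log units; within the scatter)) for ethoxycarbonyl. The exchange from ethoxycarbonyl is the largest step among these four compounds and still lies within the scatter, so two halogens and two carbonyl-bearing groups at this position all read as one level. Nothing available here bears on why the position responds so little to these exchanges.

Still open, on these data alone, is whether any group at this position can move the number beyond the scatter, for example an amine, a carboxylic acid or a longer chain. Also open, as far as these compounds go, is whether changes elsewhere on the shared core would matter more than this one.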